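Methyl on selenium: from compound 3 to compound 4

A few compounds are considered here, and "the series" means these few. Any claim that something is new, unique, unknown or untested is made for them only; others in the source may bear on it.

Of the compounds shown here, three sharing one core have been tested in a functional assay on HT-29 cells (Homo sapiens) for cytotoxicity, read by MTT assay, with a stated time of 72 h; a lower number here means a stronger inhibitor of growth, a higher number a weaker inhibitor of growth. Compound 1 `COc1ccc(CNc2nc([SeH])nc3ccccc23)cc1` gives 71600 nM in this assay. Among the compounds with values here, compound 3 `[SeH]c1nc(NCc2ccccc2)c2ccccc2n1` gives 62200 nM, and the one measured step, a 1.2-fold lower number from compound 1 to compound 3 (0.06 log units; within the scatter), lies within the scatter. Compound 2 `C[Se]c1nc(N)c2ccccc2n1` gives 27600 nM. Compound 3 thus stands second highest of the three numbers: near compound 1, and a gap beyond the scatter away from compound 2, which gives the lowest number.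

Compound 4 `C[Se]c1nc(NCc2ccccc2)c2ccccc2n1` differs from compound 3 in one place: methyl in place of hydrogen on a selenium. Within the data shown here, no measured step isolates this change. Compound 2 carries a methyl on selenium and compound 3 does not, but the two also differ at the amine, so their values only show that the methyl-bearing compound 2 gives the lower number. Among the measured compounds shown here, the single step measured, a 1.2-fold lower number from compound 1 to compound 3 (0.06 log units; within the scatter), concerns another part of the molecule and offers little guidance. The account therefore expects a modest step downward for compound 4, a 1.6-fold lower number from compound 3 to compound 4 (0.19 log units; within the scatter), with wide uncertainty. Compound 4 is estimated to give 40000 nM in this assay, within a range from 15000 nM to 110000 nM.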

Compound 4, concentration for 50% growth inhibition: 42800 nM
Compound 4: middle estimate off by 1.1-fold (0.03 log units), on the low side; the range from low to high includes it.
By their numbers in this assay, from the lowest: compounds 2, 4, 3 and 1 (each within the scatter of the next, the first and the last beyond it).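

Methyl in place of hydrogen on a selenium now has a measured step of its own in this assay, and a 1.5-fold lower number from compound 3 to compound 4 (0.16 log units; within the scatter) is what it gives. Within the data shown here, until this pair, no two compounds differed at this selenium alone, and here the change leaves the two numbers within the scatter of each other. No measurement given here bears on what lies behind this result.

As far as these compounds go, it remains open whether a longer chain on the selenium, such as ethyl, or a carboxylic acid carried on such a chain, would give a number beyond the scatter of compound 3. The compounds shown also leave open whether methyl on the selenium gives a similar step when methoxy sits on the aromatic carbon, as in compound 1.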